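Trading Benzylsulfonyl for Butylcarbamoyl on Compound 1

This account rests on a few compounds, and the source may have more. Where it says the series, first, only, none or still open, it means among the compounds named here.

Within the data shown here, in a functional assay on HUVEC cells (Homo sapiens) for inhibition (on this read-out lower numbers stand for stronger inhibition and higher numbers for weaker inhibition), compound 1 (`CN(c1ccc(NS(=O)(=O)Cc2ccccc2)cc1)c1ccnc(Nc2cccc(CS(C)(=O)=O)c2)n1`) gives 350 nM and holds the higher of the two numbers so far. Compound 3 (`CCCCNC(=O)Nc1ccc(N(C)c2ccnc(Nc3cccc(CS(C)(=O)=O)c3)n2)cc1`) has butylcarbamoyl in place of benzylsulfonyl on a nitrogen on an aromatic ring. Among the measured compounds shown here, no measured pair isolates this change. Compound 2 (`CN(c1ccc(NC(=O)Nc2ccc(OC(F)(F)F)cc2)cc1)c1ccnc(Nc2cccc(S(N)(=O)=O)c2)n1`) gives 5 nM and also carries a carbamoyl group on such a nitrogen, though it differs elsewhere too. Its number lies lower than that of compound 1, and the gap between the two is beyond the scatter. An estimated step of a 7.0-fold lower number from compound 1 to compound 3 (0.85 log units; beyond the scatter) is therefore expected in this assay as a lower number beyond the scatter. The expected value for compound 3 is 50 nM (estimated range 10 nM to 250 nM).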

Compound 3, half-maximal inhibitory concentration: 2 nM
The estimate for compound 3 lay 25-fold (1.40 log units) above the measured number; the measured number lies below the stated range.
By their numbers in this assay, from the lowest: compound 3; then compound 2; then compound 1.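

With the rest of compound 1 unchanged, putting butylcarbamoyl in place of benzylsulfonyl on a nitrogen on an aromatic ring gives a 180-fold lower number from compound 1 to compound 3 (2.24 log units; beyond the scatter) in this assay. This pair shows that the group at this one place can shift the number by a large margin, and that a group with no ring can give a low number here. No measurement shown explains this shift.

From the compounds shown here alone, because the linking group and the chain change together, their separate contributions remain open. Butylsulfonyl and benzylcarbamoyl on the same nitrogen would pull the two apart.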